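A few compounds are considered here, and "the series" means these few. Any claim that something is new, unique, unknown or untested is made for them only; others in the source may bear on it.

Going by the values given here, compound 1 `C=C1C(=O)O[C@H](C)[C@@H]1c1ccc(Br)cc1` gives 4280 nM in a functional assay on HL-60 cells (Homo sapiens) for cytotoxicity, read by MTT assay, with a stated time of 48 h (a lower number here means a stronger inhibitor, a higher number a weaker inhibitor), the lower of the two numbers so far. Its stereoisomer compound 2 `C=C1C(=O)O[C@@H](C)[C@@H]1c1ccc(Br)cc1` gives 6660 nM in this assay, and the step of a 1.6-fold higher number from compound 1 to compound 2 (0.19 log units; within the scatter) rests on configuration alone, as the fact that compounds 1 and 2 differ only in the configuration as drawn makes plain. Compound 3 `C=C1C(=O)O[C@H](C)[C@@H]1c1ccc(C)cc1` instead carries methyl in place of bromo on an aromatic carbon. Among the compounds with values here, no measured step touches a change on the aromatic ring, so the one known step, between two stereoisomers, gives no guide to direction or size in this assay. Compound 3 is therefore expected to give about 5000 nM, between 2000 nM and 15000 nM, an estimated step of a 1.2-fold higher number from compound 1 to compound 3 (0.07 log units; within the scatter) that is not expected to exceed the scatter.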

Compound 3, half-maximal inhibitory concentration: 5620 nM
For compound 3 the middle estimate is 1.1-fold (0.05 log units) below the measured one; the range from low to high includes it.
By their numbers in this assay, from the lowest: compounds 1, 3 and 2 (each within the scatter of the next).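

Methyl in place of bromo on an aromatic carbon, the only change on the aromatic ring among these compounds, gives in this assay a 1.3-fold higher number from compound 1 to compound 3 (0.12 log units; within the scatter). Going by these compounds alone, at this position, then, the two groups cannot be told apart in this read-out, and the change is no larger than the step between the stereoisomers. Nothing at hand bears on a cause for this result.

On these data alone, whether an amine, a carboxylic acid or a longer chain on this aromatic carbon would move the number beyond the scatter remains open. So does the effect of configuration when methyl replaces bromo.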